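A few compounds are considered here, and "the series" means these few. Any claim that something is new, unique, unknown or untested is made for them only; others in the source may bear on it.

The measured compounds:
Compound 1, `COc1ccc2nc(C(=O)Nc3ccc(-c4ccccc4)cc3)c(C)c(O)c2c1`, in a functional assay on A-375 cells (Homo sapiens) for antiproliferative activity, read by MTT assay, with a stated time of 24 h, tested at 100 ug/mL; a higher number here means a stronger effect of the compound at the concentration tested, a lower number a weaker effect: 66.9%
Compound 2, `Cc1c(C(=O)Nc2ccc(-c3ccccc3)cc2)nc2ccccc2c1O`, in this assay: 52.3%
Compound 3, `CCc1ccc2nc(C(=O)Nc3c(F)cc(-c4cccc(F)c4)cc3F)c(C)c(C(=O)O)c2c1`, in this assay: 71.3%

Compound 1 stands second highest of the three numbers in this assay. Compound 3 gives a number that lies within the scatter of compound 1's, so no order between the two can be read. Compound 2 lies beyond the scatter below compound 1, through the step of a number 14.6 percentage points lower from compound 1 to compound 2 (beyond the scatter), in which hydrogen takes the place of methoxy on an aromatic carbon.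

Compound 4, `COc1ccc2nc(C(=O)Nc3ccc(-c4ccccc4)cc3)c(C)c(C(=O)O)c2c1`, has not yet been measured. It differs from compound 1 in one place: carboxy in place of hydroxy on an aromatic carbon. Going by the values given here, no measured pair shows this change on its own. Among the compounds with values here, the only counted step, a number 14.6 percentage points lower from compound 1 to compound 2 (beyond the scatter), concerns a different group and is modest in size. Compound 3 also carries a carboxy, together with other differences, and its number sits within the scatter of compound 1's; that is the one hint available. The step of a number 1.1 percentage points higher from compound 1 to compound 4 (within the scatter) is therefore expected to stay within the scatter, with no clear direction. Compound 4 is estimated at 68%, with a range from 54% to 82%.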

Compound 4, a percentage reported as inhibition, at one concentration (the size of the read-out at that concentration, not a potency): 70.2%
The estimate for compound 4 lay 2.2 percentage points below the measured number; the range from low to high includes it.
By their numbers in this assay, from the lowest: compound 2; then compounds 1, 4 and 3 (each within the scatter of the next).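

In this assay, the exchange of hydroxy for carboxy on the aromatic carbon opposite the ring nitrogen gives a number 3.3 percentage points higher from compound 1 to compound 4 (within the scatter), so no order between the two compounds can be read. Going by these compounds alone, this is the first pair to show this change on its own: at this position, ortho to a methyl group, a carboxy of 3 heavy atoms takes the place of a hydroxy of 1 heavy atom with no difference that stands clear of the scatter. Nothing measured is available to explain this result.

Going by these compounds, it remains open whether an amine or a primary amide on this carbon would also stay within the scatter of compound 1. On these data alone, it is also open whether the same exchange would read alike on the core of compound 2, which has hydrogen in place of methoxy.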